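Para-chloro on the phenyl of compound 1: expected effect

The source may report more compounds than this note shows. Statements on the series, on what has been measured and on what is new or still open speak of the compounds shown alone.

Compound 1 `C=C(Br)C(=O)Nc1cccc(-c2cn3nc(-c4ccccc4)sc3n2)c1` gives 1400 nM in a functional assay on HeLa cells (Homo sapiens) for inhibition, read by cell counting, with a stated time of 4 days (on this read-out higher numbers stand for weaker inhibition and lower numbers for stronger inhibition), the lowest of the three numbers recorded so far. Compound 2 `Nc1cccc(-c2cn3nc(Cc4ccccc4)sc3n2)c1` gives 24000 nM and compound 3 `Nc1cccc(-c2cn3nc(-c4ccccc4)sc3n2)c1` gives 26000 nM. Within the data shown here, the only large step known is a 19-fold higher number from compound 1 to compound 3 (1.27 log units; beyond the scatter), which turns on the (1-bromoethenyl)carbonyl on a nitrogen on an aromatic ring; the step of a 1.1-fold higher number from compound 2 to compound 3 (0.03 log units; within the scatter) shows that phenyl in place of benzyl on an aromatic carbon changes nothing beyond the scatter.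

Compound 4 `C=C(Br)C(=O)Nc1cccc(-c2cn3nc(-c4ccc(Cl)cc4)sc3n2)c1` keeps everything in compound 1 and differs only by chloro in place of hydrogen on an aromatic carbon, on an aromatic carbon of a six-membered aromatic ring of carbon only. Among the measured compounds shown here, no measured step alters this ring by a substituent, so no direct precedent exists. For the measured compounds named here, the one ring change that is known, from benzyl to phenyl, left the number unchanged, and the (1-bromoethenyl)carbonyl that drives the potency of compound 1 is retained. The expected step is therefore a 1.2-fold lower number from compound 1 to compound 4 (0.07 log units; within the scatter), within the scatter. Compound 4 is estimated at 1200 nM, with a range from 500 nM to 3000 nM.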

Compound 4, half-maximal inhibitory concentration: 3000 nM
Compound 4: middle estimate off by 2.5-fold (0.40 log units), on the low side; measured number inside the range.
By their numbers in this assay, from the lowest: compound 1; then compound 4; then compounds 2 and 3 (each within the scatter of the next).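

In this assay, the change from phenyl to 4-chlorophenyl, para to a large group, gives a 2.1-fold higher number from compound 1 to compound 4 (0.33 log units; beyond the scatter), a modest step and the first read-out for a substituent on this ring. Among these compounds, the position is therefore not indifferent to chloro, whereas the only earlier change at this end of the molecule, a 1.1-fold higher number from compound 2 to compound 3 (0.03 log units; within the scatter), stayed within the scatter and concerned the link to the ring rather than a substituent on it. Nothing available on these compounds accounts for the higher number.

Still open, on these data alone, is whether a fluoro, a methoxy or an amine in the same place would move the number as chloro does. Also open, as far as these compounds go, is whether chloro would have the same effect on compound 3, which has no (1-bromoethenyl)carbonyl.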